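Formyl to acetyl on the aryl ether imidazoline core

A few compounds are considered here, and "the series" means these few. Any claim that something is new, unique, unknown or untested is made for them only; others in the source may bear on it.

Values in a functional assay on CHO cells for agonist activity at Alpha-2B adrenergic receptor (Homo sapiens); a lower number here means that less compound is needed, a higher number that more compound is needed for the effect:
compound 1 `CC(Oc1ccccc1OC1CC1)C1=NCCN1`: 12900 nM
compound 2 `CC(Oc1ccccc1S(C)(=O)=O)C1=NCCN1`: 10000 nM
compound 3 `CC(Oc1ccccc1C=O)C1=NCCN1`: 316 nM

Compound 3 stands lowest of the three numbers. Its nearest neighbour is compound 2, the step being a 32-fold lower number from compound 2 to compound 3 (1.50 log units; beyond the scatter); the furthest is compound 1, with a 41-fold lower number from compound 1 to compound 3 (1.61 log units; beyond the scatter). Between the two weaker compounds the step of a 1.3-fold lower number from compound 1 to compound 2 (0.11 log units; within the scatter) stays within the scatter.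

Compound 4 `CC(=O)c1ccccc1OC(C)C1=NCCN1` differs from compound 3 by methyl in place of hydrogen on a carbonyl carbon. Going by the values given here, no measured step alters the carbonyl carbon; the two large steps exchange the whole aromatic substituent and therefore bear only indirectly, showing that the formyl-bearing compound 3 gives the lowest number. A small change in this assay is expected, if any, most likely a modest rise. Compound 4 is estimated at 630 nM, range 160 nM to 3000 nM, meaning an expected 2.0-fold higher number from compound 3 to compound 4 (0.30 log units; within the scatter).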

Compound 4, half-maximal effective concentration: 295 nM
Estimate against measurement, compound 4: 2.1-fold (0.33 log units) above; the range from low to high includes it.
By their numbers in this assay, from the lowest: compounds 4 and 3 (each within the scatter of the next); then compounds 2 and 1 (each within the scatter of the next).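

In this assay the carbonyl carbon takes methyl in place of hydrogen without a readable change: a 1.1-fold lower number from compound 3 to compound 4 (0.03 log units; within the scatter) stays within the scatter. The low number is therefore not confined to formyl, as a 34-fold lower number from compound 2 to compound 4 (1.53 log units; beyond the scatter) and a 44-fold lower number from compound 1 to compound 4 (1.64 log units; beyond the scatter) both remain large steps. No evidence is available to explain why this change leaves the number where it is.

As far as these compounds go, whether a longer chain on the carbonyl carbon would hold the number remains open. So does the effect of an amine or a hydroxyl there, which would turn the ketone into an amide or a carboxylic acid.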